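Swapping the tetrazole arm for a sulfonamide

The source may hold more compounds than are shown below. What is called first, only, known or untested is meant among the compounds shown, and "the series" means these compounds.

Of the compounds shown here, three sharing one core have been measured in a functional assay (Pituitary gland cell) with Rattus norvegicus as the target; a lower number here means that less compound is needed, a higher number that more compound is needed for the effect. Compound 1 `CC(C)(N)CC(=O)N[C@@H]1CCc2ccccc2N(Cc2ccc(-c3ccccc3-c3nnn(Cc4ccccc4)n3)cc2)C1=O` gives 1 uM. Compound 2 `CC(O)Cn1nnc(-c2ccccc2-c2ccc(CN3C(=O)[C@H](NC(=O)CC(C)(C)N)CCc4ccccc43)cc2)n1` gives 0.05 uM. Compound 3 `CC(C)(N)CC(=O)N[C@@H]1CCc2ccccc2N(Cc2ccc(-c3ccccc3-c3nnn(CC(=O)O)n3)cc2)C1=O` gives 0.2 uM, the second highest of the three numbers; the step of a 5.0-fold lower number from compound 1 to compound 3 (0.70 log units; beyond the scatter) and the step of a 4.0-fold higher number from compound 2 to compound 3 (0.60 log units; beyond the scatter) frame where it stands.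

Compound 4 `CC(C)(N)CC(=O)N[C@@H]1CCc2ccccc2N(Cc2ccc(-c3ccccc3S(=O)(=O)NC(C)(C)C)cc2)C1=O` differs from compound 3 in one place: (tert-butyl)sulfamoyl in place of 2-(carboxymethyl)-2H-tetrazol-5-yl on an aromatic carbon, ortho to a large group. All three measured steps, a 20-fold lower number from compound 1 to compound 2 (1.30 log units; beyond the scatter), a 5.0-fold lower number from compound 1 to compound 3 (0.70 log units; beyond the scatter) and a 4.0-fold higher number from compound 2 to compound 3 (0.60 log units; beyond the scatter), alter only the substituent hanging from the tetrazole, whereas here the tetrazole itself leaves and a sulfonamide enters. Within the data shown here, no measured step therefore bears directly on this change; the steps show only that this region of the molecule moves the read-out over a wide range in both directions. The expected step is a 1.5-fold higher number from compound 3 to compound 4 (0.18 log units; within the scatter), with a broad uncertainty. For compound 4 the estimate in this assay is 0.3 uM, ranging from 0.05 uM to 2 uM.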

Compound 4, concentration for half-maximal effect: 4 uM
The estimate for compound 4 lay 13-fold (1.12 log units) below the measured number, and the stated range ends below it.
By their numbers in this assay, from the lowest: compound 2; then compound 3; then compound 1; then compound 4.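

In this assay, all three tetrazole compounds need less compound than the sulfonamide, with a 20-fold higher number from compound 3 to compound 4 (1.30 log units; beyond the scatter), an 80-fold higher number from compound 2 to compound 4 (1.90 log units; beyond the scatter) and a 4.0-fold higher number from compound 1 to compound 4 (0.60 log units; beyond the scatter). The earlier steps shown here showed only that the substituent on the tetrazole matters, whereas these show that exchanging the whole 2-substituted tetrazole for (tert-butyl)sulfamoyl on this aromatic carbon also shifts the read-out strongly, and that even the 2-benzyl tetrazole of compound 1 gives a lower number than compound 4. Nothing available explains why this exchange raises the number.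

This single change replaces both the ring and its substituent, so the compounds shown cannot say how much of each step belongs to the loss of the tetrazole and how much to the tert-butyl group. Also open, from the compounds shown here alone, is how a sulfamoyl group carrying a 2-hydroxypropyl chain, or a carboxylic acid directly on that aromatic carbon, would compare.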